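Chloro to iodo on the triazole-bearing phenyl ring

A few compounds are considered here, and "the series" means these few. Any claim that something is new, unique, unknown or untested is made for them only; others in the source may bear on it.

Compound 1, `CCc1cccc(-n2cc(COc3cccc(NC(=O)Nc4ccc(Cl)c(C(F)(F)F)c4)c3)nn2)c1`, gives 37900 nM in a functional assay on HepG2 cells (Homo sapiens) for inhibition, read by MTT assay, with a stated time of 72 h; on this read-out higher numbers stand for weaker inhibition and lower numbers for stronger inhibition. Compound 2, `O=C(Nc1cccc(OCc2cn(-c3cccc(Cl)c3)nn2)c1)Nc1ccc(Cl)c(C(F)(F)F)c1`, gives 2020 nM in this assay.

Going by the values given here, compound 2 holds the lowest of the two numbers measured so far; its only neighbour is compound 1, and the step from compound 1 to compound 2, a 19-fold lower number from compound 1 to compound 2 (1.27 log units; beyond the scatter), came with chloro in place of ethyl on an aromatic carbon. Compound 3, `O=C(Nc1cccc(OCc2cn(-c3cccc(I)c3)nn2)c1)Nc1ccc(Cl)c(C(F)(F)F)c1`, differs from compound 2 by iodo in place of chloro on an aromatic carbon. Among the compounds with values here, the one measured step does bear on the same position, but it exchanges an alkyl group for a halogen, not one halogen for another, so it gives no direct guide to the size of this change. Within the data shown here, no measured step swaps halogens. The expected step of a 1.3-fold lower number from compound 2 to compound 3 (0.13 log units; within the scatter) in this assay is therefore estimated to stay within the usual scatter. Compound 3 is expected at 1500 nM, with a range from 500 nM to 5000 nM.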

Compound 3, half-maximal inhibitory concentration: 4780 nM
Compound 3: middle estimate off by 3.2-fold (0.50 log units), on the low side, and the stated range covers the measured number.
By their numbers in this assay, from the lowest: compound 2; then compound 3; then compound 1.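

Swapping one halogen for another at this place does register, with a 2.4-fold higher number from compound 2 to compound 3 (0.37 log units; beyond the scatter) showing that 3-chlorophenyl and 3-iodophenyl are not interchangeable here. Iodo still keeps part of the advantage that chloro holds over ethyl, with a 7.9-fold lower number from compound 1 to compound 3 (0.90 log units; beyond the scatter) placing these three compounds in the order chloro, iodo, ethyl, from the lowest number to the highest. No measured evidence accounts for this order.

Where bromo, fluoro, a methoxy group or an amine would fall at this place remains open, so three compounds cannot yet show a wider trend across substituents. From the compounds shown here alone, it is also open whether chloro would keep its lead over iodo if the halogen sat elsewhere on this ring.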